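Swapping ethyl for vinyl at the chain end

The compounds below may be only part of what the source reports. "The series", "measured", "known", "first", "only" and "open" are said of these compounds alone.

Compound 1, `COc1cc(Cc2nc3c(N)ncnc3n2CCCO)cc(OC)c1OC`, gives 92700000 nM in a functional assay on MCF7 cells (Homo sapiens) for cytotoxicity; on this read-out higher numbers stand for an effect only at larger amounts of compound and lower numbers for an effect already at smaller amounts.
Compound 2, `COc1cc(Cc2nc3c(N)ncnc3n2CCCCCO)cc(OC)c1OC`, gives 84900000 nM in this assay.
Compound 3, `CCCCn1c(Cc2cc(OC)c(OC)c(OC)c2)nc2c(N)nc(F)nc21`, gives 185000000 nM in this assay.

Compound 3 stands highest of the three numbers, though its gap to compound 1 lies within the scatter; only its gap to compound 2 lies beyond it. Compound 4, `C=CCCn1c(Cc2cc(OC)c(OC)c(OC)c2)nc2c(N)nc(F)nc21`, is not yet measured. It differs from compound 3 by vinyl in place of ethyl on a saturated chain carbon, two bonds along the chain from an aromatic nitrogen.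

Among the measured compounds shown here, the one measured step, a 1.1-fold lower number from compound 1 to compound 2 (0.04 log units; within the scatter), concerns a change at the far end of a hydroxy-bearing chain on a different core and lies within the scatter. For the measured compounds named here, no measured step touches a change of ethyl to vinyl, so no direction can be drawn from the data; the change is small in size and adds no donor or acceptor. The expectation in this assay is therefore a step of no change at the digits printed from compound 3 to compound 4 (within the scatter), that is, none beyond the scatter. Compound 4 is estimated at 185000000 nM, with a range from 60000000 nM to 560000000 nM.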

Compound 4, half-maximal effective concentration: 102000000 nM
Estimate against measurement, compound 4: 1.8-fold (0.26 log units) above; low and high end bracket the measured number.
By their numbers in this assay, from the lowest: compounds 2, 1, 4 and 3 (each within the scatter of the next, the first and the last beyond it).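

Among the compounds shown here, this is the first measured step at this position: with vinyl in place of ethyl on a saturated chain carbon, two bonds along the chain from an aromatic nitrogen, this assay shows a 1.8-fold lower number from compound 3 to compound 4 (0.26 log units; within the scatter). On the core of compound 3, then, the butyl chain can be replaced by but-3-en-1-yl without the number moving beyond the usual scatter of this read-out. Nothing measured here explains why the two chains give numbers within the scatter of each other.

From the compounds shown here alone, whether other chain ends behave the same way stays open: an amine or a carboxylic acid at the end of the chain, or a longer chain such as hexyl, might still give a step beyond the scatter. A single pair also cannot say whether the same swap would give a similar step on the core of compound 1 .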